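A few compounds are considered here, and "the series" means these few. Any claim that something is new, unique, unknown or untested is made for them only; others in the source may bear on it.

Working notes on the series. The shared core stands in compound 1, `CCOC(=O)N1CCC(=NNC(=O)c2ccc(Cl)cc2)CC1`. In a functional assay on A549 cells (Homo sapiens) for cytotoxicity, read by MTT assay, with a stated time of 24 h (a higher number here means a weaker inhibitor, a lower number a stronger inhibitor), compound 1 gives > 400000 nM, which is a limit of the assay and not a number. Compound 2, `CCOC(=O)N1CCC(=NNC(=O)c2ccc(F)cc2)CC1`, carries fluoro in place of chloro on an aromatic carbon. In this assay compound 2 gives > 400000 nM, again a limit of the assay. The step that the two limits leave unreadable from compound 1 to compound 2 is therefore not sizeable, and both values sit at the limit of > 400000 nM in this assay, at which 2 of the 2 values shown sit. Compound 2 thus stands only at that limit, with no number to place it on.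

Compound 3, `CCOC(=O)N1CCC(=NNC(=O)c2ccc(C)cc2)CC1`, differs from compound 2 by methyl in place of fluoro on an aromatic carbon. Within the data shown here, the one measured step, a step that the two limits leave unreadable from compound 1 to compound 2, bears on it only in that it is unreadable, so neither direction nor size can be drawn from it. For compound 3 the expected step is a step that the limit leaves unreadable from compound 2 to compound 3, that is no change readable beyond the scatter. Compound 3 is accordingly estimated at 600000 nM, within a range from 150000 nM to 2500000 nM, most probably reported again only as a limit.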

Compound 3, half-maximal inhibitory concentration: > 400000 nM
Compound 3: a limit, no number; the forecaster's own chance of this, stated with the estimate: 85%; the middle value lies beyond the limit too.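

Compound 3 also stands at a limit of the assay, so neither the step from compound 2 to compound 3 nor the step from compound 1 to compound 3 can be read, and compounds 1, 2 and 3 share this position: the limit of > 400000 nM in this assay, at which 3 of the 3 values shown sit.

What the compounds shown leave open is how the para substituents rank in this assay, since no value here is a number.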